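A few compounds are considered here, and "the series" means these few. Any claim that something is new, unique, unknown or untested is made for them only; others in the source may bear on it.

Measured in an ADME assay on cells (Macrophage, Mus musculus) for cytotoxicity; a lower number here means that less compound is tolerated, a higher number that more compound is tolerated:
compound 1 `Nc1ncnc2c([C@@H]3O[C@H](CO)[C@@H](O)[C@H]3O)cnn12` – > 64000 nM
compound 2 `O=c1[nH]cnn2c([C@@H]3O[C@H](CO)C[C@H]3O)ccc12` – > 64000 nM
compound 3 `N#C[C@@]1(c2cc(Br)c3c(N)ncnn23)O[C@H](CO)[C@@H](O)[C@H]1O` – 32000 nM

The value of compound 1 in this assay is a limit of the assay and not a number. The value of compound 2 in this assay is likewise a limit, not a number. Compound 3 in this assay gives a measured number, 32000 nM. Among the compounds with values here, compound 2 thus stands at the limit of > 64000 nM in this assay, at which 2 of the 3 values shown sit, together with compound 1, and no step between measured compounds can be read off for it.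

Compound 4 `O=c1[nH]cnn2c([C@@H]3O[C@H](CO)[C@@H](O)[C@H]3O)ccc12` remains to be measured in this assay. It differs from compound 2 in a single place: hydroxy in place of hydrogen on a saturated ring carbon. The same arrangement of hydroxy groups on the five-membered non-aromatic ring is present in compound 1, whose value is also a limit. Within the data shown here, no measured pair shows this change, so no step size is available to lean on. The expectation is no move beyond the scatter in this assay, with compound 4 again reported as a limit rather than a number. Compound 4 is expected to give about 64000 nM, within 32000 nM to 128000 nM. The step estimated from compound 2 to compound 4 is a number no higher from compound 2 to compound 4 (the limit leaves the size open), within the usual scatter.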

Compound 4, half-maximal cytotoxic concentration: > 64000 nM
Compound 4 ended at the assay's limit; the forecaster's own chance of this, stated with the estimate: 80%; the middle value sits exactly at the limit.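

In this assay compound 4 gives > 64000 nM, a limit of the assay and not a number. Compound 2 also sits at a limit, so no step can be read between compound 2 and compound 4: the limit of > 64000 nM in this assay, at which 3 of the 4 values shown sit.

The compounds shown leave open whether hydroxy in place of hydrogen on a saturated ring carbon changes the read-out in this assay at all.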